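Notes on the ring-nitrogen substituent step to compound 3

This account rests on a few compounds, and the source may have more. Where it says the series, first, only, none or still open, it means among the compounds named here.

Measured compounds
Compound 1 `COc1cc(-c2nc3cc(/C=C4\SC(=O)NC4=O)ccc3[nH]2)cc(OC)c1OC`: 13600 nM
Compound 2 `COc1cc(-c2nc3cc(/C=C4\SC(=O)N(CC(=O)N5CCCC5)C4=O)ccc3[nH]2)cc(OC)c1OC`: 12700 nM

In an ADME assay on HEK-293T cells (Homo sapiens) for inhibition, read by MTT assay, with a stated time of 48 h (on this read-out lower numbers stand for stronger inhibition and higher numbers for weaker inhibition), compound 2 and compound 1 sit within the scatter of each other: a 1.1-fold lower number from compound 1 to compound 2 (0.03 log units; within the scatter). Putting the ((pyrrolidin-1-yl)carbonyl)methyl onto the amide-type nitrogen in the ring therefore left the number where it was.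

Compound 3 `COc1cc(-c2nc3cc(/C=C4\SC(=O)N(Cc5ccccc5)C4=O)ccc3[nH]2)cc(OC)c1OC` carries phenyl in place of (pyrrolidin-1-yl)carbonyl on a saturated chain carbon bound to an amide-type nitrogen in a ring. Within the data shown here, only one measured step touches this position, and that step, a 1.1-fold lower number from compound 1 to compound 2 (0.03 log units; within the scatter), was within the scatter. Among the measured compounds shown here, no measured pair shows a benzyl against a ((pyrrolidin-1-yl)carbonyl)methyl on this nitrogen, so there is no direct guide to the size of the change. Given that the one substitution seen at this nitrogen did not move the number, the step is expected to stay within the scatter as well: a 1.2-fold lower number from compound 2 to compound 3 (0.06 log units; within the scatter). Compound 3 is thus estimated at 11000 nM, with a range of 4000 nM to 30000 nM.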

Compound 3, half-maximal inhibitory concentration: 8210 nM
Compound 3: middle estimate off by 1.3-fold (0.13 log units), on the high side; the range from low to high includes it.
By their numbers in this assay, from the lowest: compounds 3, 2 and 1 (each within the scatter of the next).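

In this assay the benzyl on the amide-type nitrogen in the ring also stays within the scatter, with a 1.5-fold lower number from compound 2 to compound 3 (0.19 log units; within the scatter) and a 1.7-fold lower number from compound 1 to compound 3 (0.22 log units; within the scatter) as its two steps. This position therefore now holds a six-membered aromatic ring of carbon only as well as the (pyrrolidin-1-yl)carbonyl group with its five-membered non-aromatic ring, and the hydrogen of compound 1 cannot be told apart from either on this read-out. Nothing available explains why these three compounds read alike.

From the compounds shown here alone, whether a carboxylic acid or an amine on a longer chain at this nitrogen would give a step beyond the scatter remains open. Going by these compounds, it is equally open whether a substituted benzyl would do so, or whether a change in the shared core rather than at this nitrogen would move the number.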